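Cytotoxicity across a short alkyl-chain series on HEL cells

The source may report more compounds than this note shows. Statements on the series, on what has been measured and on what is new or still open speak of the compounds shown alone.

Measured so far:
compound 1, `CCCCCCCc1cc2cn(COCCO)c(O)nc-2n1`: >= 400000 nM (a limit of this assay)
compound 2, `CCCCCCCCCCCc1cc2cn(COCCO)c(O)nc-2n1`: 80000 nM
compound 3, `CCCCCCCCC#Cc1cc2cn(COCCO)c(=O)nc2o1`: >= 20000 nM (a limit of this assay)

Notes. The read-out is a functional assay on HEL cells (Homo sapiens), read by microscopy; a lower number here means that less compound is tolerated, a higher number that more compound is tolerated. Compound 2 gives 80000 nM. For compound 1 this assay reports only a limit, >= 400000 nM. The change hydrogen in place of butyl on a saturated chain carbon, seven bonds along the chain from an aromatic carbon gives an at least 5.0-fold higher number from compound 2 to compound 1 (0.69 log units; beyond the scatter), the endpoint sitting at the limit of >= 400000 nM in this assay, at which 1 of the 3 values shown sits.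

Compound 3 has a different core; how its core differs from that of compound 2 is not broken down here. For compound 3 this assay reports only a limit, >= 20000 nM, which is the limit of >= 20000 nM in this assay, at which 1 of the 3 values shown sits.

Compound 4, `CCCCC#Cc1cc2cn(COCCO)c(=O)nc2o1`, is not yet measured. It differs from compound 3 by hydrogen in place of butyl on a saturated chain carbon, four bonds along the chain from a triple-bonded carbon, the same kind of change as from compound 2 to compound 1, though the place here is four bonds along the chain from a triple-bonded carbon rather than seven bonds along the chain from an aromatic carbon. Because an at least 5.0-fold higher number from compound 2 to compound 1 (0.69 log units; beyond the scatter) ran toward a higher number, a step that the limit leaves unreadable from compound 3 to compound 4 is expected, most likely again reported as a limit. Compound 4 is estimated at 100000 nM, between 20000 nM and 400000 nM.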

Compound 4, minimum cytotoxic concentration: > 100000 nM
Compound 4 was reported as a limit (the forecaster's own chance of this, stated with the estimate: 80%); the middle value sits exactly at the limit.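

The step from compound 3 to compound 4 cannot be read: each compound is reported only as a limit. From the compounds shown here alone, it remains open whether hydrogen in place of butyl changes the minimum cytotoxic concentration on this core at all.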